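This account rests on a few compounds, and the source may have more. Where it says the series, first, only, none or still open, it means among the compounds named here.

Three compounds built on one shared core have been run through a functional assay on HT-29 cells (Homo sapiens) for inhibition, read by MTT assay, with a stated time of 72 h; on this read-out higher numbers stand for weaker inhibition of growth and lower numbers for stronger inhibition of growth. Compound 1 `O=S(=O)(NCCCNCc1ccc(Cl)c(Cl)c1)c1cc(C(F)(F)F)cc(C(F)(F)F)c1` gives 4700 nM in this assay, the second highest of the three numbers. Compound 2 `O=S(=O)(NCCCNCc1ccc(C(F)(F)F)cc1)c1cc(C(F)(F)F)cc(C(F)(F)F)c1` gives 2900 nM, and compound 3 `O=S(=O)(NCCCNCc1ccccc1)c1cc(C(F)(F)F)cc(C(F)(F)F)c1` gives 15000 nM. The step of a 1.6-fold lower number from compound 1 to compound 2 (0.21 log units; within the scatter) stays within the scatter, whereas a 3.2-fold higher number from compound 1 to compound 3 (0.50 log units; beyond the scatter) and a 5.2-fold higher number from compound 2 to compound 3 (0.71 log units; beyond the scatter) reach beyond it, so the ring carrying no substituent sits clearly at the weak end.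

Compound 4 `O=S(=O)(NCCCNCc1ccc(Br)cc1)c1cc(C(F)(F)F)cc(C(F)(F)F)c1` differs from compound 1 by 4-bromophenyl in place of 3,4-dichlorophenyl on a saturated chain carbon bound to an amine nitrogen; cut one bond further out, this reads 3,4-dichlorobenzyl to 4-bromobenzyl. The steps from compound 1 both bear on it: exchanging one substituted phenyl for another stayed within the scatter, while stripping the ring bare cost a modest amount. A single bromine keeps a halogen on the ring, so the expected step is a 1.1-fold higher number from compound 1 to compound 4 (0.03 log units; within the scatter), a change not expected to exceed the scatter. The estimated value for compound 4 is 5000 nM, with a range from 2500 nM to 10000 nM.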

Compound 4, concentration for 50% growth inhibition: 2200 nM
Compound 4: the middle estimate sits 2.3-fold (0.36 log units) above what was measured; measured number below the stated range.
By their numbers in this assay, from the lowest: compounds 4, 2 and 1 (each within the scatter of the next, the first and the last beyond it); then compound 3.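

At this position, on a saturated chain carbon bound to an amine nitrogen, exchanging one substituted phenyl for another can matter in this assay: 4-bromophenyl in place of 3,4-dichlorophenyl gives a 2.1-fold lower number from compound 1 to compound 4 (0.33 log units; beyond the scatter) and so goes beyond the scatter, unlike the earlier swap to 4-(trifluoromethyl)phenyl. A single bromo on the bare ring gives a 6.8-fold lower number from compound 3 to compound 4 (0.83 log units; beyond the scatter) and is the largest step in this set, so one ring substituent can account for a clear gain in growth inhibition. Bromo in place of trifluoromethyl gives a 1.3-fold lower number from compound 2 to compound 4 (0.12 log units; within the scatter) and stays within the scatter, so these two groups cannot be told apart here.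

No measurement at hand explains any of these steps. From the compounds shown here alone, it remains open whether a ring with a single chlorine or a methoxy group would match bromo, and whether a longer chain would keep these differences.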